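The compounds below may be only part of what the source reports. "The series", "measured", "known", "first", "only" and "open" are said of these compounds alone.

Within the data shown here, the three compounds measured so far share one core. Compound 1 `Nc1nc(NC2CC2)c2ncn(/C=C3/CC3(CO)CO)c2n1` gives 71500 nM in an ADME assay on BCBL1 cells (Homo sapiens) for cytotoxicity, with a stated time of 7 days; on this read-out lower numbers stand for higher toxicity in this test and higher numbers for lower toxicity in this test. Compound 2 `Nc1nc(N2CCCC2)c2ncn(/C=C3/CC3(CO)CO)c2n1` reaches only a limit in this assay, recorded as > 20000 nM. Compound 3 `Nc1nc2c(ncn2/C=C2/CC2(CO)CO)c(=O)[nH]1` likewise gives only a limit in this assay, recorded as > 20000 nM. Among the measured compounds shown here, the single step between measured neighbours, a step that the limit leaves unreadable from compound 1 to compound 2, cannot be read in size. Compound 4 `C=CCOc1nc(N)nc2c1ncn2/C=C1/CC1(CO)CO` differs from compound 2 by allyloxy in place of pyrrolidin-1-yl on an aromatic carbon. For the measured compounds named here, no measured step matches this change, and since (the limit of > 20000 nM in this assay, at which 2 of the 3 values shown sit), the numbers give little to go on; the expectation is simply that compound 4 remains weakly toxic. The step that the limit leaves unreadable from compound 2 to compound 4 is therefore estimated to stay within scatter. Compound 4 is expected at 50000 nM, within 20000 nM to 150000 nM.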

Compound 4, half-maximal cytotoxic concentration: > 20000 nM
Compound 4 gave a limit, no number; the forecaster's own chance of this, stated with the estimate: 60%; the middle value lies beyond the limit too.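

Among these compounds, the result for compound 4 is a limit and not a number, so no step to it from compound 1 or compound 2 can be read: the limit of > 20000 nM in this assay, at which 3 of the 4 values shown sit. Still open is how compound 2, compound 3 and compound 4 truly compare in this assay.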